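Swapping isopropyl for phenyl on the outer ring

A few compounds are considered here, and "the series" means these few. Any claim that something is new, unique, unknown or untested is made for them only; others in the source may bear on it.

Compound 1 `Clc1ccc(CO/N=C/c2c(-c3ccc4ccccc4c3)nc3occn23)cc1Cl` gives 370 nM in an assay on HepG2 cells for agonist activity at nuclear receptor subfamily 1 group I member 3 (Homo sapiens), read by a luciferase reporter, with a stated time of 23 h; a higher number here means that more compound is needed for the effect, a lower number that less compound is needed.
Compound 2 `Clc1cccc(-c2nc3sccn3c2/C=N/OCc2ccc(Cl)c(Cl)c2)c1` gives 1100 nM in this assay.
Compound 3 `CC(C)c1ccc(-c2nc3sccn3c2/C=N/OCc2ccc(Cl)c(Cl)c2)cc1` gives 590 nM in this assay.

Compound 3 stands second highest of these three values, but its gap to compound 1 and its gap to compound 2 both fall within the usual scatter, so the three cannot be told apart on these numbers. Compound 4 `Clc1ccc(CO/N=C/c2c(-c3ccc(-c4ccccc4)cc3)nc3sccn23)cc1Cl` is compound 3 with phenyl in place of isopropyl on an aromatic carbon. Among the compounds with values here, only one measured step touches the same ring: a 1.9-fold lower number from compound 2 to compound 3 (0.27 log units; within the scatter), which stayed within the scatter. Nothing measured shows how a phenyl at this carbon behaves, so no step beyond the scatter is expected in this assay, in either direction. Compound 4 is expected to give about 500 nM, within a range from 180 nM to 1500 nM. The expected step is a 1.2-fold lower number from compound 3 to compound 4 (0.07 log units; within the scatter).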

Compound 4, half-maximal effective concentration: "not active" (no number reported)
Compound 4 has no reported number here, so the estimate cannot be set against anything.
By their numbers in this assay, from the lowest: compounds 1, 3 and 2 (each within the scatter of the next, the first and the last beyond it).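

Within the data shown here, compound 4 is reported as not active in this assay with no number, so no step from compound 3 to compound 4 can be read. Nothing shown here bears on this result. The compounds shown leave open how far phenyl in place of isopropyl moves the number.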